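The source may hold more compounds than are shown below. What is called first, only, known or untested is meant among the compounds shown, and "the series" means these compounds.

Measured so far in an ADME assay on BJ cells (Homo sapiens) for cytotoxicity, with a stated time of 72 h; a lower number here means that less compound is needed, a higher number that more compound is needed for the effect:

compound 1, `Cc1cc(NC(=O)Nc2ncccc2C)c2ccccc2n1`: > 25000 nM, a limit of the assay rather than a number
compound 2, `Cc1cc(NC(=O)Nc2ccc(N)cc2)c2ccccc2n1`: > 25000 nM, likewise a limit
compound 3, `Cc1cc(NC(=O)Nc2ccc3[nH]cnc3c2)c2ccccc2n1`: > 25000 nM, likewise a limit

Compound 2 therefore stands at the limit of this assay, together with the two other measured compounds, a point summed up by the limit of > 25000 nM in this assay, at which 3 of the 3 values shown sit. Going by the values given here, the one step between measured compounds that differ in a single place, a step that the two limits leave unreadable from compound 1 to compound 2, cannot be read, since both ends are limits. Among the compounds with values here, no measured step, then, speaks directly to the change that leads to compound 4, `Cc1cc(NC(=O)Nc2ccc(OC(F)(F)F)cc2)c2ccccc2n1`, which differs from compound 2 as follows: trifluoromethoxy in place of amino on an aromatic carbon.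

With every shown value sitting at the limit, and no readable step to point in either direction, the expectation for compound 4 is simply that it stays in the same region, an estimated step that the limit leaves unreadable from compound 2 to compound 4. Compound 4 is estimated at 30000 nM in this assay, with a range from 10000 nM to 100000 nM, and most likely the assay will again report only a limit.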

Compound 4, half-maximal effective concentration: 25000 nM
Compound 4: middle estimate off by 1.2-fold (0.08 log units), on the high side; the measured number falls inside the stated range.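

In this assay compound 4 gives 25000 nM, a real number and the only one in this set, yet it sits at the same figure as the other compounds: the limit of > 25000 nM in this assay, at which 3 of the 4 values shown sit. Compound 2 gives > 25000 nM, which is a limit of the assay and not a number. Putting trifluoromethoxy in place of amino, on an aromatic carbon para to a large group, gives a number no higher from compound 2 to compound 4 (the limit leaves the size open), so this change shows a number no higher but no readable size.

From the compounds shown here alone, the true values of compound 1, compound 2 and compound 3 remain unknown, so the effect of this change cannot yet be sized. Also open, going by these compounds, is whether a carboxylic acid or a longer chain at this place would give a number clearly away from this figure.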